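Chlorophenyl Ester Replaced by a Benzylic Alcohol

The compounds below may be only part of what the source reports. "The series", "measured", "known", "first", "only" and "open" are said of these compounds alone.

Compound 1 `O=C(OC1(C(=O)Nc2ccc([N+](=O)[O-])cc2)CCCCC1)c1ccc(Cl)cc1` stands at the lowest of the two numbers measured in a functional assay on MCF7 cells (Homo sapiens) for inhibition, read by MTT assay, with a stated time of 72 h (a lower number here means a stronger inhibitor, a higher number a weaker inhibitor), where compound 1 gives 15 nM. Compound 2 `O=C(OC1(C(=O)Nc2ccc([N+](=O)[O-])cc2)CCCCC1)c1ccc(Br)cc1` gives 237 nM, after a step of a 16-fold higher number from compound 1 to compound 2 (1.20 log units; beyond the scatter). Compound 3 `O=C(OC1(C(=O)Nc2ccc([N+](=O)[O-])cc2)CCCCC1)C(O)c1ccccc1` differs from compound 1 by hydroxy(phenyl)methyl in place of 4-chlorophenyl on a carbonyl carbon. Among the measured compounds shown here, the only measured step exchanges one halogen for another on an aromatic carbon, so it bears only loosely on a change that removes the 4-chlorophenyl group altogether; still, that step was large and toward weaker inhibition. A weaker result is therefore expected, and the step of a 10-fold higher number from compound 1 to compound 3 (1.00 log units; beyond the scatter) is the expected size. The estimate for compound 3 is 150 nM, within 30 nM to 800 nM.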

Compound 3, half-maximal inhibitory concentration: 5.01 nM
Compound 3: the middle estimate sits 30-fold (1.48 log units) above what was measured; the measured number lies below the stated range.
By their numbers in this assay, from the lowest: compound 3; then compound 1; then compound 2.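

Replacing 4-chlorophenyl with hydroxy(phenyl)methyl on this carbonyl carbon does not weaken inhibition in this assay; it gives a 3.0-fold lower number from compound 1 to compound 3 (0.48 log units; beyond the scatter). The wider comparison gives a 47-fold lower number from compound 2 to compound 3 (1.67 log units; beyond the scatter), so a halogen on the aromatic ring is not needed for a low number here, and this position tolerates a group carrying a hydrogen-bond donor. No measurement available here explains this result.

From the compounds shown here alone, the hydroxy group and the extra carbon enter together, and their separate shares in this step remain unknown. A plain benzyl group, or a group with an amine in place of the hydroxy, would help tell them apart.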